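Swapping a tert-butyl for bromo on a sulfamate carbamate

The source may hold more compounds than are shown below. What is called first, only, known or untested is meant among the compounds shown, and "the series" means these compounds.

Of the compounds shown here, three have been measured in an assay on liver for inhibition of sterol O-acyltransferase 1 (Rattus norvegicus), using microsomes; a higher number here means a weaker inhibitor, a lower number a stronger inhibitor. Compound 1 `CC(C)NS(=O)(=O)NC(=O)Nc1c(C(C)C)cccc1C(C)C` gives 18000 nM. Compound 2 `COc1cccc(OC)c1OC(=O)NS(=O)(=O)Oc1c(C(C)C)cccc1C(C)C` gives 48000 nM; > 50000 nM (2 entries). Two of the entries for compound 2 are limits of the assay rather than numbers. The repeated results for compound 2 are summarised as the several entries of compound 2 in this assay, 48000 nM; > 50000 nM (2 entries). Compound 3 `CC(C)c1cc(C(C)(C)C)cc(C(C)C)c1OC(=O)NS(=O)(=O)Oc1c(C(C)C)cccc1C(C)C` gives 8800 nM, the lower of the two numbers available, with the number for compound 1 standing beyond the usual scatter above it.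

Compound 4 `CC(C)c1cc(Br)cc(C(C)C)c1OC(=O)NS(=O)(=O)Oc1c(C(C)C)cccc1C(C)C` has not been measured. It differs from compound 3 by bromo in place of tert-butyl on an aromatic carbon. Among the compounds with values here, no measured pair among compounds 1, 2 and 3 isolates this change, so there is no directly comparable step to lean on.

Without such a step, the expected change for compound 4 is a 1.5-fold higher number from compound 3 to compound 4 (0.17 log units; within the scatter), a modest shift towards a somewhat higher number. The estimated value for compound 4 in this assay is 13000 nM, with a range from 5000 nM to 32000 nM.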

Compound 4, half-maximal inhibitory concentration: 31000 nM
Compound 4: the middle estimate sits 2.4-fold (0.38 log units) below what was measured; the measured number falls inside the stated range.
By their numbers in this assay, from the lowest: compound 3; then compounds 1 and 4 (each within the scatter of the next).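

In this assay, the ring position meta to two isopropyl groups and para to a large group now gives its first readable single change: bromo in place of tert-butyl yields a 3.5-fold higher number from compound 3 to compound 4 (0.55 log units; beyond the scatter). The position is therefore not indifferent to what sits on it, since exchanging a group of 4 heavy atoms for one of 1 heavy atom moves the number beyond the usual scatter, even though neither group has hydrogen-bond donors, hydrogen-bond acceptors or a net charge. Nothing in the data shown bears on why the number moves in this direction.

With only tert-butyl and bromo seen at this position, a single step cannot separate an effect of losing the carbon atoms of tert-butyl from one specific to bromo. Going by these compounds, how an amine, a carboxylic acid or a longer chain at this position would read in this assay remains open, as does whether the same swap would give a similar step on a different core.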